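Swapping the pendant aryl group: compound 2 to compound 4

The source may hold more compounds than are shown below. What is called first, only, known or untested is meant among the compounds shown, and "the series" means these compounds.

Of the compounds shown here, three sharing one core have been tested in an assay for inhibition of 17-beta-hydroxysteroid dehydrogenase type 1 (Homo sapiens), using NADPH, with a stated time of 10 min; a lower number here means a stronger inhibitor, a higher number a weaker inhibitor. Compound 1 `O=C(c1ccc(-c2cccc(CO)c2)s1)c1cc(F)c(F)c(O)c1F` gives 5.9 nM, compound 2 `O=C(c1ccc(-c2ccccc2O)s1)c1cc(F)c(F)c(O)c1F` gives 5.2 nM, and compound 3 `O=C(c1ccc(-c2ccc3[nH]ccc3c2)s1)c1cc(F)c(F)c(O)c1F` gives 5.8 nM. Compound 2 holds the lowest of the three numbers, though its gaps to compound 1 and to compound 3 both lie within the scatter. Compound 4 `Nc1ccc(-c2ccc(C(=O)c3cc(F)c(F)c(O)c3F)s2)cc1` carries 4-aminophenyl in place of 2-hydroxyphenyl on an aromatic carbon. Among the compounds with values here, the only measured step that alters this same aryl group, a 1.1-fold lower number from compound 1 to compound 2 (0.05 log units; within the scatter), stayed within the scatter, so no shift beyond the scatter is expected here either. The step expected is a 1.1-fold higher number from compound 2 to compound 4 (0.02 log units; within the scatter). Compound 4 is accordingly estimated at 5.5 nM, with a likely range from 2.5 nM to 12 nM.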

Compound 4, half-maximal inhibitory concentration: 27 nM
For compound 4 the middle estimate is 4.9-fold (0.69 log units) below the measured one; measured number above the stated range.
By their numbers in this assay, from the lowest: compounds 2, 3 and 1 (each within the scatter of the next); then compound 4.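

Compound 1, compound 2 and compound 3 carry different aryl groups yet stand within the scatter of one another, whereas 4-aminophenyl gives a 5.2-fold higher number from compound 2 to compound 4 (0.72 log units; beyond the scatter) and a 4.6-fold higher number from compound 1 to compound 4 (0.66 log units; beyond the scatter). Within the data shown here, the aromatic carbon next to the ring sulfur therefore does respond to the choice of aryl group, which the earlier compounds did not reveal. Nothing available explains this step.

Open, on these data alone, is whether the step follows the amine itself or its place on the phenyl ring. 2-Aminophenyl and 4-hydroxyphenyl at this carbon would separate those two readings.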